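The source may report more compounds than this note shows. Statements on the series, on what has been measured and on what is new or still open speak of the compounds shown alone.

In a functional assay on HCT-116 cells (Homo sapiens) for antiproliferative activity, read by MTT assay, with a stated time of 68 h (on this read-out lower numbers stand for stronger inhibition and higher numbers for weaker inhibition), the measured compounds are:

Compound 1 `O=S(=O)(Nc1ccc(F)c(C#Cc2ccc3[nH]ncc3c2)c1F)c1cccnc1`: > 10000 nM, which is a limit.
Compound 2 `O=S(=O)(Nc1ccc(F)c(C#Cc2cnc3ccnn3c2)c1F)c1cccnc1`: 10000 nM.

Among the compounds with values here, compound 2 holds the only actual number so far, and it marks weak inhibition. Compound 3 `Cc1n[nH]c2ncc(C#Cc3c(F)ccc(NS(=O)(=O)c4cccnc4)c3F)cc12` has not been measured. It differs from compound 2 on a triple-bonded carbon: a group of 10 heavy atoms (7 carbon, 3 nitrogen; one five-membered aromatic ring with 2 hetero atoms, one six-membered aromatic ring with 1 hetero atom) in place of a group of 9 heavy atoms (6 carbon, 3 nitrogen; one five-membered aromatic ring with 2 hetero atoms, one six-membered aromatic ring with 2 hetero atoms), on a triple-bonded carbon. Within the data shown here, only one measured step bears on this change, a number no higher from compound 1 to compound 2 (the limit leaves the size open), and its size stays open since one end is a limit. That step also swapped the group on the triple-bonded carbon, so it offers a weak guide and no firm size. A modest move toward stronger inhibition is expected, with wide uncertainty. The expected step is a 2.5-fold lower number from compound 2 to compound 3 (0.40 log units; beyond the scatter). For compound 3 the estimated value is 4000 nM. The expected range for compound 3 runs from 400 nM to 20000 nM.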

Compound 3, half-maximal inhibitory concentration: 4630 nM
Compound 3: the middle estimate sits 1.2-fold (0.06 log units) below what was measured, within the range that was stated.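

In this assay, within the data shown here, a change of group on the triple-bonded carbon now has a readable size for the first time: a 2.2-fold lower number from compound 2 to compound 3 (0.33 log units; beyond the scatter). This modest gain shows that the number can move at this position, though compound 3 remains a weak inhibitor, and the comparison with the other bicyclic group gives an at least 2.1-fold lower number from compound 1 to compound 3 (0.33 log units; beyond the scatter). Compound 1 holds a limit and not a number, which leaves that second step open at one end: the limit of > 10000 nM in this assay, at which 1 of the 3 values shown sits.

The swap from compound 2 to compound 3 alters the ring atoms, the heavy-atom count and the hydrogen-bond donor count together, so the compounds shown cannot say which of these matters. They also leave open whether a different group on the triple-bonded carbon, such as a simple phenyl ring or an aminopyridine, would give a much lower number.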